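Ethoxycarbonyl Added to a Thiol-Bearing Amide Series

This account rests on a few compounds, and the source may have more. Where it says the series, first, only, none or still open, it means among the compounds named here.

Of the compounds shown here, two have been measured in a functional assay, with a stated time of 30 min, tested at 200 uM; on this read-out lower numbers stand for a weaker effect and higher numbers for a stronger effect at the one concentration tested. Compound 1, with the structure `CCOC(=O)C(CS)NC(=O)c1cc(C(C)(C)C)c(O)c(C(C)(C)C)c1`, gives 85% in this assay. Compound 2, with the structure `Cc1c(C)c2c(c(C)c1O)CCC(C)(C(=O)NCCS)O2`, gives 93% in this assay. Compound 2 holds the higher of the two numbers, but the gap to compound 1 is within the usual scatter, so the two compounds cannot be separated on these data. Compound 3, with the structure `CCOC(=O)C(CS)NC(=O)C1(C)CCc2c(C)c(O)c(C)c(C)c2O1`, is the next compound, still unmeasured in this assay. Relative to compound 2 it differs in one respect: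

ethoxycarbonyl in place of hydrogen on a saturated chain carbon bound to an amide-type nitrogen and a saturated chain carbon

Going by the values given here, no step between measured compounds is available to size this change. With both measured values already high, the step from compound 2 to compound 3 is expected to be small, a number 5 percentage points lower from compound 2 to compound 3 (within the scatter), and not clearly beyond the scatter in either direction. Compound 3 is therefore estimated to give 88% in this assay, with a range of 70% to 100%.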

Compound 3, a percentage reported as activity, at one concentration (the size of the read-out at that concentration, not a potency): 93%
Estimate against measurement, compound 3: 5 percentage points below; low and high end bracket the measured number.
By their numbers in this assay, from the lowest: compounds 1, 2 and 3 (each within the scatter of the next).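

Ethoxycarbonyl in place of hydrogen on a saturated chain carbon bound to an amide-type nitrogen and a saturated chain carbon gives, in this assay, no change at the digits printed from compound 2 to compound 3 (within the scatter). Going by these compounds alone, this is the first step read at this position, and it shows that the position takes this group, with its 5 heavy atoms and no ring, without a change in the read-out at the one concentration tested. No measured evidence accounts for this result.

As far as these compounds go, a single concentration gives no potency, so any difference between the two compounds at lower concentrations remains unknown. From the compounds shown here alone, it is also open whether a carboxylic acid, an amine or a longer chain at this carbon would leave the read-out as unchanged as ethoxycarbonyl does.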